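This account rests on a few compounds, and the source may have more. Where it says the series, first, only, none or still open, it means among the compounds named here.

Compound 1 `COc1ccc(CN(C(=O)Nc2ccc(F)c(Cl)c2)n2cnnc2)cc1OC`: 30100 nM
Compound 2 `O=C(NCc1ccccc1)N(Cc1ccccn1)n1cnnc1`: > 50000 nM

In a functional assay on MCF7 cells (Homo sapiens) for cytotoxicity, read by MTT assay, with a stated time of 48 h (on this read-out lower numbers stand for stronger inhibition and higher numbers for weaker inhibition), compound 1 gives 30100 nM. For compound 2 the picture is different: in this assay compound 2 gives > 50000 nM, and this is a limit of the measurement rather than a number. It is the limit of > 50000 nM in this assay, at which 1 of the 2 values shown sits. Compound 2 therefore stands at the weak end of what has been measured, with no exact value known.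

Compound 3 `O=C(NC1CCCCC1)N(Cc1ccccn1)n1cnnc1` differs from compound 2 in one place: cyclohexyl in place of benzyl on an amide-type nitrogen. For the measured compounds named here, no measured pair shows this change, so its effect in this assay cannot be read off from the data. Because compound 2 sits at a limit > 50000 nM, any step towards weaker inhibition would stay hidden behind that limit. The step that the limit leaves unreadable from compound 2 to compound 3 is expected to lie within the scatter. Compound 3 is expected to give 60000 nM, in the range 20000 nM to 200000 nM, most probably again reported only as a limit.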

Compound 3, half-maximal inhibitory concentration: 46900 nM
For compound 3 the middle estimate is 1.3-fold (0.11 log units) above the measured one; the measured number falls inside the stated range.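

Replacing benzyl with cyclohexyl on the amide-type nitrogen gives an exact reading in this assay, where compound 3 gives 46900 nM. So a non-aromatic ring of carbon at this place still leaves a value that can be measured, whereas compound 2 has only a limit, not a number: the limit of > 50000 nM in this assay, at which 1 of the 3 values shown sits. Read against that limit, the change gives an at least 1.0-fold lower number from compound 2 to compound 3 (0.02 log units; that floor lies within the scatter), which shows only a floor, so the true size of the step remains unknown.

The compounds shown leave open how far the number would move with an open chain such as hexyl, or with an amine, at this same place. They also leave open whether the swap from benzyl to cyclohexyl would act in the same way with the other groups of the core of compound 1.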